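The compounds below may be only part of what the source reports. "The series", "measured", "known", "first", "only" and "open" are said of these compounds alone.

Three compounds of the series have numbers in an ADME assay on Caco-2 cells (Homo sapiens) for permeability, read by LC-MS, with a stated time of 2 h, tested at 3 uM; a lower number here means that the compound crosses the layer more slowly, a higher number that the compound crosses the layer faster. Compound 1 `CCN(c1cc2oc(-c3ccc(F)cc3)c(C(=O)NC)c2cc1-c1cc(C)c(OC)c(C(=O)NC2(c3ncccn3)CC2)c1)S(C)(=O)=O` gives 33 nm/s. Compound 2 `CCN(c1cc2oc(-c3ccc(F)cc3)c(C(=O)NC)c2cc1-c1cc(F)c(F)c(C(=O)NC2(c3ncccn3)CC2)c1)S(C)(=O)=O` gives 79 nm/s. Compound 3 `CCN(C(=O)OC)c1cc2oc(-c3ccc(F)cc3)c(C(=O)NC)c2cc1-c1ccc(OC)c(C(=O)NC2(c3ncccn3)CC2)c1` gives 24 nm/s, the lowest of the three numbers; the gap to compound 1 lies within the scatter, the gap to compound 2 beyond it. Compound 4 `CCN(C(=O)C(F)(F)F)c1cc2oc(-c3ccc(F)cc3)c(C(=O)NC)c2cc1-c1ccc(OC)c(C(=O)NC2(c3ncccn3)CC2)c1` has not yet been measured in this assay. The change from compound 3 to compound 4 is trifluoromethyl in place of methoxy on a carbonyl carbon. For the measured compounds named here, no pair of measured compounds differs only at this place, so the size of such a step cannot be read from the numbers in hand; the three measured compounds differ from one another at several places at once. The expected step is a 1.7-fold higher number from compound 3 to compound 4 (0.22 log units; within the scatter), upward in direction but not clearly beyond the scatter. For compound 4 the estimate in this assay is 40 nm/s, with a range from 15 nm/s to 110 nm/s.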

Compound 4, apparent permeability: 42 nm/s
Estimate against measurement, compound 4: 1.1-fold (0.02 log units) below; the range from low to high includes it.
By their numbers in this assay, from the lowest: compounds 3, 1, 4 and 2 (each within the scatter of the next, the first and the last beyond it).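

In this assay the series now has a pair differing in one place, and the step reads a 1.8-fold higher number from compound 3 to compound 4 (0.24 log units; within the scatter) for trifluoromethyl in place of methoxy on a carbonyl carbon. For the compounds shown here, this position on the amide-type nitrogen therefore takes this exchange without a step beyond the scatter, which the earlier compounds, differing at several places at once, could not show; one pair does not fix a general size for the change. Nothing measured in hand accounts for the size of this step.

Still open, from the compounds shown here alone, is whether a dimethylamino group or a longer chain such as propyl on the same carbonyl carbon would give a step beyond the scatter. Also open, going by these compounds, is whether this exchange gives a similar step with the other substituents of compound 2 in place.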